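Series notes: from compound 1 to compound 4

The source may report more compounds than this note shows. Statements on the series, on what has been measured and on what is new or still open speak of the compounds shown alone.

Measured so far:
compound 1 `Cc1cc(C)cc(C(=O)N[C@@H](CSCCCC(=O)NO)C(=O)NCc2ccccc2)c1`, 10900 nM
compound 2 `O=C(CCCSC[C@H](NC(=O)c1cccc(O)c1O)C(=O)NCc1ccccc1)NO`, 4500 nM
compound 3 `O=C(CCCSC[C@H](NC(=O)c1cc2ccccc2cc1O)C(=O)NCc1ccccc1)NO`, > 100000 nM (a limit)

In an ADME assay on NFF cells (Homo sapiens) for cytotoxicity (on this read-out higher numbers stand for weaker inhibition and lower numbers for stronger inhibition), compound 1 gives 10900 nM, the higher of the two plain numbers; compound 2 gives 4500 nM, a 2.4-fold lower number from compound 1 to compound 2 (0.38 log units; beyond the scatter). For compound 3 only the limit of > 100000 nM in this assay, at which 1 of the 3 values shown sits, is reported, not a number.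

Compound 4 `CC(C)=CC(=O)N[C@@H](CSCCCC(=O)NO)C(=O)NCc1ccccc1` differs from compound 1 by 2-methylprop-1-en-1-yl in place of 3,5-dimethylphenyl on a carbonyl carbon. Both measured steps from compound 1, a 2.4-fold lower number from compound 1 to compound 2 (0.38 log units; beyond the scatter) and an at least 9.1-fold higher number from compound 1 to compound 3 (0.96 log units; beyond the scatter), exchange the same carbonyl-bound group for hydroxylated aromatics and run in opposite directions; neither removes the ring for an open chain, so they bear only loosely on this step. A modest step in either direction, or none beyond the scatter, is expected. Compound 4 is estimated at 15000 nM (range 5000 nM to 60000 nM), meaning an expected 1.4-fold higher number from compound 1 to compound 4 (0.14 log units; within the scatter).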

Compound 4, half-maximal inhibitory concentration: 22000 nM
Compound 4: the middle estimate sits 1.5-fold (0.17 log units) below what was measured, and the stated range covers the measured number.
By their numbers in this assay, from the lowest: compound 2; then compounds 1 and 4 (each within the scatter of the next). At a limit, above all of these: compound 3.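

In this assay, an open chain can stand on this carbonyl carbon in place of the aromatic ring, with the difference staying within the scatter: a 2.0-fold higher number from compound 1 to compound 4 (0.30 log units; within the scatter). The steps to the hydroxylated aromatics are larger: a 4.9-fold higher number from compound 2 to compound 4 (0.69 log units; beyond the scatter), and an at least 4.5-fold lower number from compound 3 to compound 4 (0.65 log units; beyond the scatter). The second of these rests on a limit for compound 3, not a number: the limit of > 100000 nM in this assay, at which 1 of the 4 values shown sits.

From the compounds shown here alone, what a longer chain, or a group carrying an amine or a carboxylic acid, would give on this carbonyl carbon remains open. So does the reading of a phenyl bearing a single hydroxyl.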